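From bromo to trifluoromethoxy: expected cell toxicity

The source may hold more compounds than are shown below. What is called first, only, known or untested is meant among the compounds shown, and "the series" means these compounds.

Compound 1 `CN(C)c1cc2[nH]c(C3CCCCC3)nc2cc1NC(=O)c1ccc(Br)cc1` was examined in an ADME assay on Vero cells (Chlorocebus sabaeus) for cytotoxicity, read by resazurin assay, with a stated time of 3 days; on this read-out lower numbers stand for stronger inhibition and higher numbers for weaker inhibition. In this assay compound 1 gives > 100 ug/mL, which is a limit of the assay and not a number. Compound 2 `CCN(CC)c1cc2[nH]c(C3CCCCC3)nc2cc1NC(=O)c1ccc(Br)cc1` gives > 100 ug/mL in this assay, again only a limit. For the measured compounds named here, the step that the two limits leave unreadable from compound 1 to compound 2 therefore cannot be sized; the only evidence is the limit of > 100 ug/mL in this assay, at which 2 of the 2 values shown sit. Compound 3 `CN(C)c1cc2[nH]c(C3CCCCC3)nc2cc1NC(=O)c1ccc(OC(F)(F)F)cc1` differs from compound 1 by trifluoromethoxy in place of bromo on an aromatic carbon. Going by the values given here, no measured step speaks to this change, so no step beyond the usual scatter is expected. Compound 3 is expected to give about 100 ug/mL in this assay, between 50 ug/mL and 200 ug/mL, most probably again as a limit. The expected step of a number no higher from compound 1 to compound 3 (the limit leaves the size open) is accordingly small.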

Compound 3, half-maximal inhibitory concentration: > 100 ug/mL
Compound 3 ended at the assay's limit; the forecaster's own chance of this, stated with the estimate: 80%; the middle value sits exactly at the limit.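

No step from compound 1 to compound 3 can be read, since both results are limits of this assay and not numbers: the limit of > 100 ug/mL in this assay, at which 3 of the 3 values shown sit.

The compounds shown leave open whether bromo and trifluoromethoxy differ at all in this assay, and how far past the limit the true values lie.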